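Swapping a methoxy for a hydroxy on the aryl ring

This account rests on a few compounds, and the source may have more. Where it says the series, first, only, none or still open, it means among the compounds named here.

Measured compounds:
compound 1, `COc1cc(C)cc(-c2c(-c3ccnc(-c4ccc(N(C)C)cc4)c3)cnn2CC#N)c1`: 76.6 nM
compound 2, `COc1cc(C)cc(-c2nn(CC#N)cc2-c2ccnc(-c3ccc(N(C)C)cc3)c2)c1`: 350 nM
compound 3, `COc1cc(C)cc(-c2nn(CC#N)cc2-c2ccc(-c3cccc(C(C)=O)c3)nc2)c1`: 2140 nM

The three compounds share a core and were tested in a functional assay on HCT-15 cells (Homo sapiens) for inhibition, read by sulforhodamine B assay, with a stated time of 48 h; a lower number here means a stronger inhibitor of growth, a higher number a weaker inhibitor of growth. Compound 2 sits second highest among the three numbers: compound 1 gives the lower number, compound 3 the higher one, and both gaps lie beyond the scatter of this assay.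

The unmeasured compound 4, `Cc1cc(O)cc(-c2nn(CC#N)cc2-c2ccnc(-c3ccc(N(C)C)cc3)c2)c1`, differs from compound 2 in a single place: hydrogen in place of methyl on an oxygen on an aromatic ring. Put another way, the methoxy becomes a hydroxy, so the 3-methoxy-5-methylphenyl becomes a 3-hydroxy-5-methylphenyl.

Going by the values given here, no measured pair shows this change, so its effect is unknown here. Compound 4 is expected to be a somewhat weaker inhibitor of growth than compound 2, with the step of a 2.0-fold higher number from compound 2 to compound 4 (0.30 log units; within the scatter) likely beyond the scatter but not large. For compound 4 the estimated value in this assay is 700 nM, within a range of 180 nM to 2800 nM.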

Compound 4, concentration for 50% growth inhibition: 3360 nM
Compound 4: middle estimate off by 4.8-fold (0.68 log units), on the low side; the measured number lies above the stated range.
By their numbers in this assay, from the lowest: compound 1; then compound 2; then compounds 3 and 4 (each within the scatter of the next).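

In this assay, a hydrogen in place of the methyl on the oxygen of the 3-methoxy-5-methylphenyl gives a 9.6-fold higher number from compound 2 to compound 4 (0.98 log units; beyond the scatter), a clear loss of growth inhibition. Going by these compounds alone, this is the first comparison here in which only one place changes, so it isolates this position and shows that the methoxy cannot be traded for a hydroxy without cost, even though just one carbon leaves. Nothing measured here explains the loss.

On these data alone, what an ethoxy, a longer ether chain or an amine at this position would do remains open, so it is unclear whether the methyl itself matters or any group on the oxygen would serve. As far as these compounds go, whether the same swap on compound 1 would cost as much also remains open.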